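Moving the Methyl on the Benzyl Group of Compound 3

A few compounds are considered here, and "the series" means these few. Any claim that something is new, unique, unknown or untested is made for them only; others in the source may bear on it.

Three compounds have been measured in an assay on isolated protein for inhibition of Fatty-acid amide hydrolase 1 (Homo sapiens); on this read-out higher numbers stand for weaker inhibition and lower numbers for stronger inhibition:

Compound 1 `CC(C)S(=O)(=O)N1CCC(CCCC(=O)c2ncco2)CC1` gives 140 nM.
Compound 2 `CC(C)OC(=O)N1CCC(CCCC(=O)c2ncco2)CC1` gives 4 nM.
Compound 3 `Cc1cccc(CN2CCC(CCCC(=O)c3ncco3)CC2)c1` gives 90 nM.

Compound 3 stands second highest of these three numbers. Its nearest neighbour is compound 1, and the step of a 1.6-fold lower number from compound 1 to compound 3 (0.19 log units; within the scatter) lies within the scatter, so the two cannot be ordered. The step of a 23-fold higher number from compound 2 to compound 3 (1.35 log units; beyond the scatter) is large and well beyond the scatter.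

Compound 4 `Cc1ccc(CN2CCC(CCCC(=O)c3ncco3)CC2)cc1` differs from compound 3 by 4-methylphenyl in place of 3-methylphenyl on a saturated chain carbon bound to an amine nitrogen in a ring. Within the data shown here, none of the measured steps bears directly on this change: a 35-fold lower number from compound 1 to compound 2 (1.54 log units; beyond the scatter), a 1.6-fold lower number from compound 1 to compound 3 (0.19 log units; within the scatter) and a 23-fold higher number from compound 2 to compound 3 (1.35 log units; beyond the scatter) all exchange the whole group on the ring nitrogen, whereas here the benzyl group is kept and only its methyl is relocated on the aromatic ring. Those steps show that the group on the nitrogen can shift the number a great deal, but they give no guidance on methyl position within a benzyl. Without a guiding step, the expected step is a 1.1-fold higher number from compound 3 to compound 4 (0.05 log units; within the scatter), within the scatter and in no firm direction. Compound 4 is therefore estimated at 100 nM, with a range from 30 nM to 350 nM.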

Compound 4, half-maximal inhibitory concentration: 400 nM
Beside the measured number, compound 4's estimate is 4.0-fold (0.60 log units) below it, outside the stated range (above it).
By their numbers in this assay, from the lowest: compound 2; then compounds 3 and 1 (each within the scatter of the next); then compound 4.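

In this assay, moving the methyl is not a neutral change: going from 3-methylbenzyl to 4-methylbenzyl gives a 4.4-fold higher number from compound 3 to compound 4 (0.65 log units; beyond the scatter), even though the two groups contain the same atoms. Methyl position therefore separates two benzyl compounds that stand differently against the others: compound 3 lies within the scatter of compound 1, whereas a 2.9-fold higher number from compound 1 to compound 4 (0.46 log units; beyond the scatter) lies beyond it, and a 100-fold higher number from compound 2 to compound 4 (2.00 log units; beyond the scatter) is a wider gap than the one separating compound 2 from compound 3. Nothing available explains why this position matters.

On these data alone, it remains open how a plain benzyl group with no methyl, or 2-methylbenzyl, would compare with these two. As far as these compounds go, it is also open whether a larger group in the same place, such as 4-methoxybenzyl, would follow the direction seen with 4-methylbenzyl.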